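This account rests on a few compounds, and the source may have more. Where it says the series, first, only, none or still open, it means among the compounds named here.

Measured in a functional assay on MDA-MB-231 cells (Homo sapiens) for inhibition, read by CCK-8 assay, with a stated time of 48 h; a higher number here means a weaker inhibitor of growth, a lower number a stronger inhibitor of growth:
- compound 1 `Cc1ccccc1Nc1nc(Nc2ccc(N3CCN(C)CC3)cn2)ncc1Cl`: 7470 nM
- compound 2 `CN1CCN(c2ccc(Nc3ncc(Cl)c(NCc4ccccc4)n3)nc2)CC1`: 24800 nM
- compound 3 `CC(C)c1cccc(Nc2nc(Nc3ccc(N4CCN(C)CC4)cn3)ncc2Cl)c1`: 5590 nM

Compound 3 sits at the low end of these numbers, but it shares that end with compound 1, as a 1.3-fold lower number from compound 1 to compound 3 (0.13 log units; within the scatter) shows. Compound 2 stands apart, with a 4.4-fold lower number from compound 2 to compound 3 (0.65 log units; beyond the scatter).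

The next compound, compound 4 `CC(C)c1ccccc1Nc1nc(Nc2ccc(N3CCN(C)CC3)cn2)ncc1Cl`, keeps the same atoms but joins them differently: 2-isopropylphenyl in place of 3-isopropylphenyl on a nitrogen on an aromatic ring. Within the data shown here, no measured pair shows this exact move, so the estimate has to lean on nearby changes. The closest guide is the swap of 2-methylphenyl for 3-isopropylphenyl, which gave a 1.3-fold lower number from compound 1 to compound 3 (0.13 log units; within the scatter). The other step beyond the scatter, a 3.3-fold higher number from compound 1 to compound 2 (0.52 log units; beyond the scatter), also involves benzyl, a group that compound 4 does not carry. In this assay, a small shift that stays within the scatter is therefore the likeliest outcome, perhaps slightly upward, towards compound 1.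

Among the measured compounds shown here, the expected change is a 1.2-fold higher number from compound 3 to compound 4 (0.07 log units; within the scatter), which is no real step.

For compound 4 the estimated value is 6500 nM, with an expected range from 3000 nM to 14000 nM.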

Compound 4, concentration for 50% growth inhibition: 4090 nM
For compound 4 the middle estimate is 1.6-fold (0.20 log units) above the measured one, and the stated range covers the measured number.
By their numbers in this assay, from the lowest: compounds 4, 3 and 1 (each within the scatter of the next); then compound 2.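

In this assay, moving the isopropyl group, so that 2-isopropylphenyl stands in place of 3-isopropylphenyl on the nitrogen, gives a change that stays within the scatter (a 1.4-fold lower number from compound 3 to compound 4 (0.14 log units; within the scatter)), so these two placements cannot be told apart. Isopropyl in place of methyl on an aromatic carbon also leaves the result within the scatter (a 1.8-fold lower number from compound 1 to compound 4 (0.26 log units; within the scatter)), which means that compounds 1, 3 and 4 form one group despite their different substituents on the phenyl ring, while 2-isopropylphenyl in place of benzyl gives the only new step beyond the scatter (a 6.1-fold lower number from compound 2 to compound 4 (0.78 log units; beyond the scatter)). Nothing in the available data explains why these phenyl groups give such similar numbers or why compound 2 stands apart.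

On these data alone, all the substituents on that phenyl ring here are plain alkyl groups, so it remains open whether a methoxy group, a fluorine atom or a carboxylic acid at the same place would keep the number close to those of compounds 1, 3 and 4. As far as these compounds go, it also remains open whether a longer chain, such as a tert-butyl or hexyl group, would still fit this flat picture or would finally produce a step beyond the scatter.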